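Notes on the step from compound 2 to compound 3

The compounds below may be only part of what the source reports. "The series", "measured", "known", "first", "only" and "open" are said of these compounds alone.

Compound 1 `COc1cc(OC)c(-c2coc3cc(OCC=C(C)C)ccc3c2=O)cc1OC` gives 1090 nM
Compound 2 `COc1cc(OC)c(-c2coc3cc(OCc4cccc(F)c4)ccc3c2=O)cc1OC` gives 2440 nM

In a functional assay on B16 cells (Mus musculus) for antiproliferative activity, read by MTT assay, with a stated time of 24 h (on this read-out lower numbers stand for stronger inhibition and higher numbers for weaker inhibition), compound 2 holds the higher of the two numbers (2440 nM) and so is the weaker of the pair. Compound 3 `COc1cc(OC)c(-c2coc3cc(OCc4ccccc4Br)ccc3c2=O)cc1OC` carries 2-bromophenyl in place of 3-fluorophenyl on a saturated chain carbon bound to an oxygen on an aromatic ring. Among the measured compounds shown here, only one measured step touches this place, and it involves a different group: a 2.2-fold higher number from compound 1 to compound 2 (0.35 log units; beyond the scatter) is modest and beyond the scatter. For the measured compounds named here, no measurement yet compares 2-bromophenyl with 3-fluorophenyl. A step no larger than that modest one is therefore expected in this assay with no firm direction. The estimated change is small (a 1.1-fold lower number from compound 2 to compound 3 (0.04 log units; within the scatter)) and is expected to stay within the scatter. For compound 3 the estimated value is 2200 nM with an expected range from 1000 nM to 4800 nM as the working bounds.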

Compound 3, half-maximal inhibitory concentration: 8900 nM
For compound 3 the middle estimate is 4.0-fold (0.61 log units) below the measured one; measured number above the stated range.
By their numbers in this assay, from the lowest: compound 1; then compound 2; then compound 3.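

In this assay the exchange of 3-fluorophenyl for 2-bromophenyl gives a 3.6-fold higher number from compound 2 to compound 3 (0.56 log units; beyond the scatter) and thus shows that this place, on a saturated chain carbon bound to an oxygen on an aromatic ring, separates two halogen-bearing phenyl groups and not only a phenyl group from 2-methylprop-1-en-1-yl. With an 8.2-fold higher number from compound 1 to compound 3 (0.91 log units; beyond the scatter) added to the earlier step, compound 1 holds the lowest number of the three, and its steps to both others lie beyond the scatter. No available measurement accounts for the difference between the two phenyl groups.

Halogen and ring place change together from compound 2 to compound 3, so 3-bromophenyl or 2-fluorophenyl would be needed to separate them. Going by these compounds, how an amine or a carboxylic acid would read at this place remains open.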